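From 3,5-dimethylphenyl to 3,5-dichlorophenyl in the series

The source may hold more compounds than are shown below. What is called first, only, known or untested is meant among the compounds shown, and "the series" means these compounds.

In a functional assay on RS4-11 cells (Homo sapiens) for inhibition, read by CCK-8 assay, with a stated time of 48 h (a lower number here means a stronger inhibitor, a higher number a weaker inhibitor), compound 3 (`Cc1cc(C)cc(NC(=O)NCCNS(=O)(=O)c2ccc(-c3ccccc3OCc3ccccc3)s2)c1`) reads > 50000 nM, which is a limit and not a number. Compound 4 (`O=C(NCCNS(=O)(=O)c1ccc(-c2ccccc2OCc2ccccc2)s1)Nc1cc(Cl)cc(Cl)c1`) is the next to be placed. The change is 3,5-dichlorophenyl in place of 3,5-dimethylphenyl on an amide-type nitrogen. Among the compounds with values here, no measured step covers this exchange.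

Compound 1 (`O=C(NCCNS(=O)(=O)c1ccc(-c2ccccc2OCc2cccc(O)c2)s1)Nc1cc(Cl)cc(Cl)c1`) already carries 3,5-dichlorophenyl and reads > 50000 nM, again a limit. Compound 2 (`O=C(NCCNS(=O)(=O)c1ccc(-c2ccccc2Oc2ccc(O)c(O)c2)s1)Nc1cc(Cl)cc(Cl)c1`) carries it too and gives 4500 nM. Within the data shown here, the one measured step, an at least 11-fold lower number from compound 1 to compound 2 (1.04 log units; beyond the scatter), is large, but it comes from 3,4-dihydroxyphenyl in place of 3-hydroxybenzyl on an oxygen on an aromatic ring. That is a different place from the one changed here, so its size does not carry over. The wider picture is the limit of > 50000 nM in this assay, at which 2 of the 3 values shown sit.

The expectation rests mainly on compound 1, whose > 50000 nM is a limit, so 3,5-dichlorophenyl alone is not expected to bring a clear gain. The expected change is small, towards a lower number if there is any: an at least 1.4-fold lower number from compound 3 to compound 4 (0.15 log units; that floor lies within the scatter). A report of the limit alone is also quite possible. Compound 4 is estimated at 35000 nM, with an expected range from 12000 nM to 50000 nM.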

Compound 4, half-maximal inhibitory concentration: > 20000 nM
Compound 4 was reported as a limit (the forecaster's own chance of this, stated with the estimate: 60%); the middle value does not contradict the limit.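

Exchanging 3,5-dimethylphenyl for 3,5-dichlorophenyl on the amide-type nitrogen does not by itself bring the benzyl ether series to a measured number in this assay: compound 4 stays a limit, and the steps linking it to compound 3 and to compound 1 cannot be read. With 3,5-dichlorophenyl held constant, the only readable difference lies in the group on the oxygen, where benzyl in place of 3,4-dihydroxyphenyl gives an at least 4.4-fold higher number from compound 2 to compound 4 (0.64 log units; beyond the scatter). Compound 2 remains the only one of the four compounds with a number rather than a limit, and the limit of compound 4 is not the one seen for the others: the limit of > 20000 nM in this assay, at which 1 of the 4 values shown sits.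

Open, as far as these compounds go, is whether the exchange on the amide-type nitrogen has any readable size when 3,4-dihydroxyphenyl sits on the oxygen, the only setting here that gives a number. Also open, from the compounds shown here alone, is how a carboxylic acid or an amine in place of the hydroxy groups of compound 2 would read in this assay.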